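The source may hold more compounds than are shown below. What is called first, only, known or untested is meant among the compounds shown, and "the series" means these compounds.

Working notes on the series. Compound 1 `CCCCCCCCOC(=O)C(O)Cn1cnc2c(N)ncnc21` carries an octyl group on the oxygen next to a carbonyl group; in a functional assay on HeLa cells (Homo sapiens) for cytotoxicity (on this read-out lower numbers stand for higher toxicity in this test and higher numbers for lower toxicity in this test), compound 1 gives 100 ug/mL. Compound 2 `CC(C)OC(=O)C(O)Cn1cnc2c(N)ncnc21` reaches only a limit of this assay, > 400 ug/mL. Compound 3 `CC(C)COC(=O)C(O)Cn1cnc2c(N)ncnc21` likewise stands at a limit of this assay, > 400 ug/mL. Compound 3 therefore sits at the limit where two of the three values sit (the limit of > 400 ug/mL in this assay, at which 2 of the 3 values shown sit), with no number of its own. Both readable steps, an at least 4.0-fold higher number from compound 1 to compound 2 (0.60 log units; beyond the scatter) and an at least 4.0-fold higher number from compound 1 to compound 3 (0.60 log units; beyond the scatter), carry the value from a number to the limit when a shorter branched group replaces the long chain; the step that the two limits leave unreadable from compound 2 to compound 3 is not readable from two limits.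

Compound 4 `CC(C)(C)OC(=O)C(O)Cn1cnc2c(N)ncnc21` differs from compound 3 by tert-butyl in place of isobutyl on an oxygen next to a carbonyl group. Going by the values given here, the only comparison between two branched groups on this oxygen gives no readable size, so the expectation rests on compound 3 remaining at its limit: the step of a number no higher from compound 3 to compound 4 (the limit leaves the size open) is expected to be none beyond the scatter. Compound 4 is therefore expected near 400 ug/mL, within 200 ug/mL to 800 ug/mL.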

Compound 4, minimum cytotoxic concentration: > 400 ug/mL
Compound 4 ended at the assay's limit (the forecaster's own chance of this, stated with the estimate: 75%); the middle value sits exactly at the limit.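

Tert-butyl on this oxygen stands at the same limit as isopropyl and isobutyl in this assay, so all three branched groups shown give a limit and octyl in compound 1 remains the only group with a number of its own: the limit of > 400 ug/mL in this assay, at which 3 of the 4 values shown sit.

Replacing octyl with tert-butyl gives an at least 4.0-fold higher number from compound 1 to compound 4 (0.60 log units; beyond the scatter), the same reading as the two earlier steps away from compound 1. The steps among compound 2, compound 3 and compound 4 join limits and cannot be read, so no order among these branched groups can be stated.

From the compounds shown here alone, whether the number of compound 1 follows from chain length or belongs to octyl alone stays open. Also open, going by these compounds, is how a straight butyl or hexyl chain, or a benzyl group, on this oxygen would read in this assay.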